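From Chloro to Methoxy on the Shared Core

The source may report more compounds than this note shows. Statements on the series, on what has been measured and on what is new or still open speak of the compounds shown alone.

Of the compounds shown here, three with one common core have been tested in a functional assay on SGC-7901 cells (Homo sapiens) for antiproliferative activity, read by sulforhodamine B assay, with a stated time of 72 h; on this read-out lower numbers stand for stronger inhibition and higher numbers for weaker inhibition. Compound 1 `N#Cc1ccc(NC(=S)N/N=C/c2ccc3ccccc3n2)cc1` gives 23700 nM. Compound 3 `S=C(N/N=C/c1ccc2ccccc2n1)Nc1ccc(Cl)cc1` gives 87600 nM in this assay, the higher of the two numbers, with compound 1 as its nearest neighbour after a 3.7-fold higher number from compound 1 to compound 3 (0.57 log units; beyond the scatter). For compound 2 `Cc1cccc(NC(=S)N/N=C/c2ccc3ccccc3n2)c1` the assay reports only a limit, > 100000 nM, as recorded in the limit of > 100000 nM in this assay, at which 1 of the 3 values shown sits. The comparison an at least 1.1-fold lower number from compound 2 to compound 3 (0.05 log units; that floor lies within the scatter) therefore rests on that limit and shows no separation.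

Compound 4 `COc1ccc(NC(=S)N/N=C/c2ccc3ccccc3n2)cc1` has not yet been measured in this assay. Relative to compound 3 the change is methoxy in place of chloro on an aromatic carbon. Among the measured compounds shown here, the one measured step that touches the same position is a 3.7-fold higher number from compound 1 to compound 3 (0.57 log units; beyond the scatter), where replacing cyano with chloro moved the number by a modest amount toward weaker inhibition; no measured step involves methoxy, so its direction is open. Compound 4 is expected to stay near compound 3 or drift further upward, with the estimated step of a 1.1-fold lower number from compound 3 to compound 4 (0.04 log units; within the scatter). The number for compound 4 in this assay is estimated at 80000 nM, within a range from 30000 nM to 200000 nM, with a real chance that only a limit is returned.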

Compound 4, half-maximal inhibitory concentration: 89600 nM
Beside the measured number, compound 4's estimate is 1.1-fold (0.05 log units) below it, within the range that was stated.
By their numbers in this assay, from the lowest: compound 1; then compounds 3 and 4 (each within the scatter of the next). At a limit, above all of these: compound 2.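

In this assay, methoxy in place of chloro on an aromatic carbon, para to a large group, is a 1.0-fold higher number from compound 3 to compound 4 (0.01 log units; within the scatter), so the two groups cannot be told apart here, even though methoxy brings a hydrogen-bond acceptor that chloro lacks. Cyano, which until now had been compared at this position with chloro alone, now separates from a second group as well: the step is a 3.8-fold higher number from compound 1 to compound 4 (0.58 log units; beyond the scatter), and it stands alongside the earlier 3.7-fold higher number from compound 1 to compound 3 (0.57 log units; beyond the scatter). Among the three compounds that differ only at this position, compound 1 is therefore the only one that separates from the others, and this holds for cyano, chloro and methoxy only.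

Compound 2 is recorded only as a limit. On these data alone, the step to 4-methoxyphenyl, an at least 1.1-fold lower number from compound 2 to compound 4 (0.04 log units; that floor lies within the scatter), rests on that limit and shows no separation, so the 3-methylphenyl group stays unplaced against 4-methoxyphenyl: the limit of > 100000 nM in this assay, at which 1 of the 4 values shown sits. It also remains open whether an amine, a carboxylic acid or a trifluoromethyl group at this position would join compound 1 or stay with compound 3 and compound 4.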